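This account rests on a few compounds, and the source may have more. Where it says the series, first, only, none or still open, it means among the compounds named here.

Compound 1 `O=c1[nH]c(=O)n([C@H]2C[C@H](O)[C@@H](CO)O2)cc1-c1cn(CCC(F)(F)C(F)(F)C(F)(F)C(F)(F)F)nn1` and compound 2 `O=c1[nH]c(=O)n([C@H]2C[C@H](O)[C@@H](CO)O2)cc1-c1cn(CCC(F)(F)C(F)(F)C(F)(F)C(F)(F)C(F)(F)C(F)(F)F)nn1` share one core and differ only in the length of a fluorinated chain. In a functional assay on PC-3 cells (Homo sapiens) for antiproliferative activity, read by sulforhodamine B assay (a lower number here means a stronger inhibitor of growth, a higher number a weaker inhibitor of growth), compound 1 gives 97.8 uM, and compound 2 gives 115 uM; the step is a 1.2-fold higher number from compound 1 to compound 2 (0.07 log units; within the scatter), so the two numbers sit within the scatter of each other. Compound 3 `O=c1[nH]c(=O)n([C@H]2C[C@H](O)[C@@H](CO)O2)cc1-c1cn(CCC(F)(F)C(F)(F)F)nn1` comes from compound 1 by a change in the opposite direction, (fluoro in place of 1,1,2,2,2-pentafluoroethyl on a saturated chain carbon bound to two fluorine atoms and a saturated chain carbon). Among the measured compounds shown here, the only step that bears on this, lengthening the chain, stayed within the scatter, so no step beyond the scatter is expected here either, a 1.0-fold higher number from compound 1 to compound 3 (0.01 log units; within the scatter). Compound 3 is therefore estimated at 100 uM, between 50 uM and 200 uM.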

Compound 3, concentration for growth inhibition (reported as GI): 96.4 uM
Compound 3: the middle estimate sits 1.0-fold (0.02 log units) above what was measured; measured number inside the range.
By their numbers in this assay, from the lowest: compounds 3, 1 and 2 (each within the scatter of the next).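

Among the compounds shown here, compound 1 had so far been compared only with a longer chain, and here the chain is shorter, with fluoro in place of 1,1,2,2,2-pentafluoroethyl. In this assay this gives (a 1.0-fold lower number from compound 1 to compound 3 (0.01 log units; within the scatter)), so at this position neither shortening nor lengthening the fluorinated chain produces a step beyond the scatter. No measurement at hand explains this.

Still open, on these data alone, is whether a plain hydrocarbon chain without fluorine would behave the same way. The same question applies to a chain ending in an amine or a carboxylic acid.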